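The source may hold more compounds than are shown below. What is called first, only, known or untested is meant among the compounds shown, and "the series" means these compounds.

In a functional assay on Huh-7 cells (Homo sapiens) for cytotoxicity, read by MTT assay, with a stated time of 72 h (on this read-out higher numbers stand for lower toxicity in this test and lower numbers for higher toxicity in this test), compound 1 `CCS(=O)(=O)N1CCC2(CC1)OOC1(CCCCC1)OO2` gives > 100 ug/mL, which is a limit and not a number. Compound 2 `CCCS(=O)(=O)N1CCC2(CC1)OOC1(CCCCC1)OO2` gives > 100 ug/mL, also a limit. On these data alone, compound 3 `COc1ccc(S(=O)(=O)N2CCC3(CC2)OOC2(CCCCC2)OO3)cc1` stands at > 100 ug/mL, again only a limit, so its exact place is unknown. Compound 4 `O=S(=O)(c1ccc(Br)cc1F)N1CCC2(CC1)OOC1(CCCCC1)OO2` carries 4-bromo-2-fluorophenyl in place of 4-methoxyphenyl on a sulfonyl sulfur. Two measured changes at that sulfur bear on this: a step that the two limits leave unreadable from compound 1 to compound 3 and a step that the two limits leave unreadable from compound 2 to compound 3. Among the compounds with values here, neither has a readable size, and the series so far shows only (the limit of > 100 ug/mL in this assay, at which 3 of the 3 values shown sit). No change beyond the usual scatter is therefore expected, and the estimated step is a number no higher from compound 3 to compound 4 (the limit leaves the size open). Compound 4 is expected at 100 ug/mL, with an estimated range of 45 ug/mL to 200 ug/mL.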

Compound 4, half-maximal cytotoxic concentration: > 100 ug/mL
Compound 4 was reported as a limit (the forecaster's own chance of this, stated with the estimate: 70%); the middle value sits exactly at the limit.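

Compound 4, like compound 1, compound 2 and compound 3, is reported only as a limit, so no step among them can be read: the limit of > 100 ug/mL in this assay, at which 4 of the 4 values shown sit.

The compounds shown leave open whether any group on the sulfonyl sulfur changes the result in this assay.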